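The source may report more compounds than this note shows. Statements on the series, on what has been measured and on what is new or still open speak of the compounds shown alone.

Measured so far:
compound 1 `CNc1ncnc2c1c(I)cn2[C@@H]1O[C@H](CO)[C@@H](O)[C@H]1O`, > 100000 nM
compound 2 `COc1ncnc2c1c(I)cn2[C@@H]1O[C@H](CO)[C@@H](O)[C@H]1O`, 1150 nM
compound 3 `CNc1ncnc2c1c(-c1ccco1)cn2[C@@H]1O[C@H](CO)[C@@H](O)[C@H]1O`, 180 nM

All three were tested in a functional assay on CCRF-CEM cells (Homo sapiens), read by MTT assay, with a stated time of 72 h; a higher number here means a weaker inhibitor, a lower number a stronger inhibitor. For compound 1 the value given, > 100000 nM, is a limit of the assay and not a number (the limit of > 100000 nM in this assay, at which 1 of the 3 values shown sits). Compound 2 differs from compound 1 by methoxy in place of methylamino on an aromatic carbon, and this brought an at least 86-fold lower number from compound 1 to compound 2 (1.93 log units; beyond the scatter). Compound 3 differs from compound 1 by furan-2-yl in place of iodo on an aromatic carbon, which brought an at least 550-fold lower number from compound 1 to compound 3 (2.74 log units; beyond the scatter); compound 3 also gives a number below that of compound 2, beyond the scatter.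

Compound 4 `COc1ncnc2c1c(-c1ccco1)cn2[C@@H]1O[C@H](CO)[C@@H](O)[C@H]1O` has not yet been measured in this assay. It differs from compound 3 by methoxy in place of methylamino on an aromatic carbon, the same change that was made from compound 1 to compound 2, while the two cores differ by furan-2-yl in place of iodo on an aromatic carbon. The earlier step rests on a limit and its true size is not known because of the limit of > 100000 nM in this assay, at which 1 of the 3 values shown sits. Compound 4 is therefore estimated to give a step of a 4.5-fold lower number from compound 3 to compound 4 (0.65 log units; beyond the scatter), which is expected to be smaller than the earlier one. The estimate for compound 4 is 40 nM, between 5 nM and 200 nM.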

Compound 4, half-maximal inhibitory concentration: 20 nM
Estimate against measurement, compound 4: 2.0-fold (0.30 log units) above, within the range that was stated.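

In this assay, methoxy in place of methylamino gives a 9.0-fold lower number from compound 3 to compound 4 (0.95 log units; beyond the scatter), and the same change is larger on the core of compound 1: the same change on two cores in this assay, an at least 86-fold lower number (1.93 log units; beyond the scatter) from compound 1 to compound 2 and a 9.0-fold lower number (0.95 log units; beyond the scatter) from compound 3 to compound 4, at least 9.6-fold (0.98 log units) apart, beyond the scatter of two such steps. Furan-2-yl in place of iodo gives a 58-fold lower number from compound 2 to compound 4 (1.76 log units; beyond the scatter), and this change too is smaller here than on the core of compound 1: the same change on two cores in this assay, an at least 550-fold lower number (2.74 log units; beyond the scatter) from compound 1 to compound 3 and a 58-fold lower number (1.76 log units; beyond the scatter) from compound 2 to compound 4, at least 9.6-fold (0.98 log units) apart, beyond the scatter of two such steps. Compound 1 stands at a limit and not a number, so the pairs show that the direction of each change carries from one core to the other while its size does not, but they do not show how large the true gap between the steps is: the limit of > 100000 nM in this assay, at which 1 of the 4 values shown sits.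

The four compounds cover only methylamino and methoxy at one place, and only iodo and furan-2-yl at the other. From the compounds shown here alone, it remains open whether the same pattern would hold for a primary amine, a longer alkoxy chain, or a phenyl or thiophene ring in place of the furan.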